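A few compounds are considered here, and "the series" means these few. Any claim that something is new, unique, unknown or untested is made for them only; others in the source may bear on it.

Measured so far in a functional assay on RAW264.7 cells (Mus musculus) for inhibition, read by Griess assay, with stated times of 2 h and 24 h; on this read-out higher numbers stand for weaker inhibition and lower numbers for stronger inhibition:
compound 1 `C#CCOc1cc(O)c2c(c1)O[C@H](c1ccc(OC)c(O)c1)CC2=O` gives 20900 nM
compound 2 `COc1ccc([C@@H]2CC(=O)c3c(O)cc(OCc4cn(Cc5ccccc5C(F)(F)F)nn4)cc3O2)cc1O` gives 12500 nM
compound 3 `COc1ccc([C@@H]2CC(=O)c3c(O)cc(OCc4cn(Cc5ccccc5)nn4)cc3O2)cc1O` gives 11000 nM

Compound 3 is not separated from compound 1 or compound 2, as its gaps to both lie within the scatter. Compound 4 `COc1ccc([C@@H]2CC(=O)c3c(O)cc(OCc4cn(CC5CC5)nn4)cc3O2)cc1O` differs from compound 3 by cyclopropyl in place of phenyl on a saturated chain carbon bound to an aromatic nitrogen. For the measured compounds named here, the one measured step (a 1.1-fold lower number from compound 2 to compound 3 (0.06 log units; within the scatter)) also touches that phenyl and stays within the scatter. Compound 1, which lacks the benzyl group, gives 20900 nM and lies within the scatter of compound 3. No step beyond the scatter is therefore expected in this assay, in either direction. The expected change is a 1.2-fold higher number from compound 3 to compound 4 (0.07 log units; within the scatter) and remains an estimate. For compound 4 the estimated value is 13000 nM (range 6000 nM to 30000 nM).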

Compound 4, half-maximal inhibitory concentration: 11900 nM
Compound 4: the middle estimate sits 1.1-fold (0.04 log units) above what was measured; low and high end bracket the measured number.
By their numbers in this assay, from the lowest: compounds 3, 4, 2 and 1 (each within the scatter of the next).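

In this assay, cyclopropyl in place of phenyl gives a 1.1-fold higher number from compound 3 to compound 4 (0.03 log units; within the scatter), and cyclopropyl in place of 2-(trifluoromethyl)phenyl gives a 1.1-fold lower number from compound 2 to compound 4 (0.02 log units; within the scatter), so at this position an aromatic ring is not needed to keep the number in this range. The full 1-(cyclopropylmethyl)-1H-1,2,3-triazol-4-yl in place of ethynyl gives a 1.8-fold lower number from compound 1 to compound 4 (0.24 log units; within the scatter). No supporting data bear on the reason for these results.

On these data alone, whether any group at this position can move the number beyond the scatter remains open. An amine, a carboxylic acid or a longer chain in place of cyclopropyl would test this.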